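This account rests on a few compounds, and the source may have more. Where it says the series, first, only, none or still open, it means among the compounds named here.

In a toxicity assay on HeLa cells (Homo sapiens) for cytotoxicity, read by MTT assay, with a stated time of 48 h (on this read-out higher numbers stand for weaker inhibition and lower numbers for stronger inhibition), compound 1 (`N#C/C(=C\c1ccc(-c2ccc(-c3ccc(N(c4ccccc4)c4ccccc4)cc3)s2)s1)C(=O)O`) gives 21900 nM. Compound 2 (`COC(=O)/C(C#N)=C/c1ccc(-c2ccc(-c3ccc(N(c4ccccc4)c4ccccc4)cc3)s2)s1`) reads > 100000 nM, which is a limit of the assay and not a number. Compound 3 (`CC(C)(C)OC(=O)/C(C#N)=C/c1ccc(-c2ccc(-c3ccc(N(c4ccccc4)c4ccccc4)cc3)s2)s1`) has tert-butyl in place of methyl on an oxygen next to a carbonyl group. Going by the values given here, the one measured step at this oxygen, an at least 4.5-fold higher number from compound 1 to compound 2 (0.65 log units; beyond the scatter), put methyl in place of hydrogen, so the larger ester is also expected to remain weak. The expected step is a number no higher from compound 2 to compound 3 (the limit leaves the size open), with none expected beyond the scatter. Compound 3 is estimated at 100000 nM, with an expected range of 40000 nM to 200000 nM.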

Compound 3, half-maximal inhibitory concentration: > 100000 nM
Compound 3: a limit, no number; the forecaster's own chance of this, stated with the estimate: 70%; the middle value lies on the limit itself.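

In this assay compound 3 reads > 100000 nM, which is a limit of the assay and not a number. With tert-butyl on the oxygen of the acid group, the result is an at least 4.5-fold higher number from compound 1 to compound 3 (0.65 log units; beyond the scatter), so a second and larger ester also stands apart from the acid. The step between compound 2 and compound 3 cannot be read: the limit of > 100000 nM in this assay, at which 2 of the 3 values shown sit.

On these data alone, how far either ester lies past that limit stays open. So does whether an ethyl group, or a chain ending in an amine, on this oxygen would give a number rather than a limit.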